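A few compounds are considered here, and "the series" means these few. Any claim that something is new, unique, unknown or untested is made for them only; others in the source may bear on it.

Compound 1, drawn as `CN(C)CCCCCCCCOc1ccc2oc(-c3ccccc3)cc(=O)c2c1`, was tested in an assay on isolated protein (Cavia porcellus) with Sigma non-opioid intracellular receptor 1 (Homo sapiens) as the target, read by radioligand binding (on this read-out lower numbers stand for stronger inhibition and higher numbers for weaker inhibition), where compound 1 gives 143 nM. Among the measured compounds shown here, its only measured companion is compound 2, `O=c1cc(C2CCCCC2)oc2ccc(OCCCCCCN3CCC(O)CC3)cc12`, which in this assay gives 46 nM. For the measured compounds named here, of the two numbers, compound 1 holds the higher one, and the gap between the two lies beyond the usual scatter of repeated measurements; no single-point step links the two structures, so nothing more is drawn from that pair.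

The step now followed leads from compound 1 to compound 3, drawn as `NCCCCCCOc1ccc2oc(-c3ccccc3)cc(=O)c2c1`. The two structures differ in one place: amino in place of 2-(dimethylamino)ethyl on a saturated chain carbon, six bonds along the chain from an oxygen on an aromatic ring.

Because compound 1 already stands at 143 nM and this exchange strips the chain back to a bare amino group, the step from compound 1 to compound 3 is expected to move toward weaker inhibition, by a 2.8-fold higher number from compound 1 to compound 3 (0.45 log units; beyond the scatter), a change that would go beyond the scatter. On that basis compound 3 is expected to give 400 nM in this assay, with a plausible range from 120 nM to 1500 nM.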

Compound 3, half-maximal inhibitory concentration: 3700 nM
The estimate for compound 3 lay 9.3-fold (0.97 log units) below the measured number; measured number above the stated range.
By their numbers in this assay, from the lowest: compound 2; then compound 1; then compound 3.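

Among the compounds shown here, this step gives the first reading of a change in one place: in this assay, amino in place of 2-(dimethylamino)ethyl on a saturated chain carbon, six bonds along the chain from an oxygen on an aromatic ring, produces a 26-fold higher number from compound 1 to compound 3 (1.41 log units; beyond the scatter) with the rest of the structure held constant. The far end of this chain is therefore not a neutral place in this assay, since an exchange confined to it moves the number well beyond the scatter and toward weaker inhibition. Nothing measured here explains the size of that shift, and no supporting data bear on this step.

For the compounds shown here, the single step also changes two things together, as the exchange removes both the two methyl groups on the nitrogen and the ethyl stretch of chain that carries them, so their separate shares stay unresolved. A dimethylamino group on the chain length of compound 3, or an amino group on the chain length of compound 1, would divide the step into those two parts, and a pyrrolidine or morpholine at the chain end would test how far the result extends to other amines.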